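This account rests on a few compounds, and the source may have more. Where it says the series, first, only, none or still open, it means among the compounds named here.

Of the compounds shown here, three have been measured in an assay for displacement of a labelled ligand from growth hormone secretagogue receptor type 1 (Homo sapiens), read by scintillation counting; on this read-out higher numbers stand for weaker inhibition and lower numbers for stronger inhibition. Compound 1 `Cc1nc2ncc(Oc3ccc(-c4ccccc4)cc3)cc2c(=O)n1C[C@H]1CCCN(C(C)C)C1` gives 1.7 nM. Compound 2 `Cc1nc2ncc(Oc3ccc(F)c4cccnc34)nc2c(=O)n1C[C@H]1CCCN(C(C)C)C1` gives 1.9 nM. Compound 3 `Cc1nc2ncc(Oc3ccc(Br)cc3F)nc2c(=O)n1C[C@H]1CCCN(C(C)C)C1` gives 0.05 nM, the lowest of the three numbers; its distance from compound 1 and from compound 2 is in each case beyond the scatter, so on these numbers it is the strongest binder of the three.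

The step now followed leads from compound 3 to compound 4 `Cc1nc2ncc(Oc3ccc4c(c3)ncn4C)nc2c(=O)n1C[C@H]1CCCN(C(C)C)C1`, through (1-methyl-1H-benzimidazol-5-yl in place of 4-bromo-2-fluorophenyl on an oxygen on an aromatic ring). Among the measured compounds shown here, the one measured step that bears on this is a 38-fold lower number from compound 2 to compound 3 (1.58 log units; beyond the scatter), in which a group built from two aromatic rings gave way to a single six-membered ring carrying a bromine and a fluorine, and the number fell sharply. Going to compound 4 runs that kind of change backwards: the single ring with its halogens leaves and a two-ring group returns, though with a five-membered ring holding two nitrogen atoms rather than the quinolinyl of compound 2. A large rise in the number is therefore expected for compound 4 in this assay, roughly back to the level of compound 2 at 1.9 nM, giving an expected step of a 30-fold higher number from compound 3 to compound 4 (1.48 log units; beyond the scatter). The estimate for compound 4 is 1.5 nM, within a range from 0.3 nM to 8 nM.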

Compound 4, inhibition constant: 5 nM
Compound 4: middle estimate off by 3.3-fold (0.52 log units), on the low side, within the range that was stated.
By their numbers in this assay, from the lowest: compound 3; then compounds 1 and 2 (each within the scatter of the next); then compound 4.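

At this place on the oxygen, this assay shows a 100-fold higher number from compound 3 to compound 4 (2.00 log units; beyond the scatter), so replacing 4-bromo-2-fluorophenyl with 1-methyl-1H-benzimidazol-5-yl gives up almost all of the strong binding of compound 3. Among the compounds shown here, the two groups built from two aromatic rings are not equivalent either: a 2.6-fold higher number from compound 2 to compound 4 (0.42 log units; beyond the scatter), a modest step but one beyond the scatter, so 1-methyl-1H-benzimidazol-5-yl gives weaker binding here than 5-fluoroquinolin-8-yl, and both fall well short of the single halogen-bearing ring of compound 3. No measurement shown explains why these groups differ in this way.

The compounds shown leave open whether the bromine, the fluorine or the pair of them accounts for the low number of compound 3, which a plain phenyl or a phenyl carrying only one of these halogens could help to separate. They also leave open whether the methyl on the benzimidazole matters, since a benzimidazolyl group bearing a hydrogen or an ethyl group there would be needed to judge that.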